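This account rests on a few compounds, and the source may have more. Where it says the series, first, only, none or still open, it means among the compounds named here.

This piece follows a small set of amides tested for their ability to switch on a cold-sensing ion channel. Compound 1 `Cc1ccc(OCC(=O)N(Cc2cccs2)C2CCCCC2)cc1` carries a cyclohexyl on its amide-type nitrogen. In an assay on HEK293 cells for agonist activity at transient receptor potential cation channel subfamily M member 8 (Homo sapiens), read by fluorescence and calcium flux, with a stated time of 15 min (a lower number here means that less compound is needed, a higher number that more compound is needed for the effect), compound 1 gives 40000 nM, the highest number among the three measured compounds. Compound 2 `Cc1ccc(/C=C/C(=O)N(Cc2cccs2)c2ccn[nH]2)cc1` gives 0.004 nM in this assay, and compound 3 `COc1ccc2oc(C(=O)N(Cc3cccs3)c3ccn[nH]3)cc2c1` gives 1.1 nM; both lie far below compound 1, with compound 3 the nearer of the two.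

Compound 4 `Cc1ccc(OCC(=O)N(Cc2cccs2)c2cnn(C)c2)cc1` has not yet been measured. It differs from compound 1 in one place: 1-methyl-1H-pyrazol-4-yl in place of cyclohexyl on an amide-type nitrogen. For the measured compounds named here, the two potent compounds also carry an aromatic ring on that nitrogen, though a different one, and their linkers differ from the one kept in compound 4, so a large step downward is expected but with wide uncertainty. The expected step is a 20-fold lower number from compound 1 to compound 4 (1.30 log units; beyond the scatter). Compound 4 is therefore estimated at 2000 nM in this assay, within a range from 50 nM to 40000 nM.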

Compound 4, half-maximal effective concentration: 63000 nM
For compound 4 the middle estimate is 32-fold (1.50 log units) below the measured one; measured number outside the range, above it.
By their numbers in this assay, from the lowest: compound 2; then compound 3; then compounds 1 and 4 (each within the scatter of the next).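

With the rest of the molecule kept as in compound 1, putting 1-methyl-1H-pyrazol-4-yl in place of cyclohexyl on the amide-type nitrogen gives a 1.6-fold higher number from compound 1 to compound 4 (0.20 log units; within the scatter) in this assay. In this pair, the assay does not separate a six-membered non-aromatic ring of carbon only from a five-membered aromatic ring with 2 hetero atoms, although the entering group has 2 hydrogen-bond acceptors and the leaving group has 0. Nothing at hand explains why the two groups give such similar numbers.

From the compounds shown here alone, whether a phenyl or pyridyl ring, or an open chain such as isopropyl, on this nitrogen would shift the number remains open. So does whether any such swap would have a larger effect on a different chain attached to the carbonyl.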